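A few compounds are considered here, and "the series" means these few. Any claim that something is new, unique, unknown or untested is made for them only; others in the source may bear on it.

Compound 1 `CCCSc1nc(N/N=C/c2ccccc2Cl)c2nnn(Cc3ccccc3)c2n1` gives 13800 nM in a functional assay on MCF7 cells (Homo sapiens) for antiproliferative activity, read by MTT assay, with a stated time of 72 h; a higher number here means a weaker inhibitor, a lower number a stronger inhibitor.
Compound 2 `CCCSc1nc(N/N=C/c2cccc(Cl)c2)c2nnn(Cc3ccccc3)c2n1` gives > 64000 nM in this assay, a limit of the assay rather than a number.

Of the two measured compounds only compound 1 yields a number, while compound 2 sits at the limit (the limit of > 64000 nM in this assay, at which 1 of the 2 values shown sits), so compound 2 stands at the weak end of what is shown and its true value is known only as lying beyond that limit. Among the measured compounds shown here, the single measured step, an at least 4.6-fold higher number from compound 1 to compound 2 (0.66 log units; beyond the scatter), moves the chlorine to another position on the phenyl and weakens inhibition beyond the scatter. The next step, to compound 3 `CCCSc1nc(N/N=C/c2c[nH]c3ccccc23)c2nnn(Cc3ccccc3)c2n1`, is a different kind of change: 1H-indol-3-yl in place of 3-chlorophenyl on a carbon with a double bond to nitrogen. For the measured compounds named here, no measured step replaces the whole group on that carbon, so the step from compound 1 to compound 2 bears on it only by showing that this group matters. Compound 3 is expected to land at 30000 nM (range 6000 nM to 150000 nM). The step of an at least 2.1-fold lower number from compound 2 to compound 3 (0.32 log units; beyond the scatter) is expected to go toward stronger inhibition, with the reservation that the starting point is itself only a limit.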

Compound 3, half-maximal inhibitory concentration: 9010 nM
Estimate against measurement, compound 3: 3.3-fold (0.52 log units) above; the range from low to high includes it.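

In this assay, 1H-indol-3-yl on the carbon with a double bond to nitrogen gives an at least 7.1-fold lower number from compound 2 to compound 3 (0.85 log units; beyond the scatter), so the loss seen with 3-chlorophenyl is not shared by every group at this place. Against 2-chlorophenyl, the same group gives a 1.5-fold lower number from compound 1 to compound 3 (0.19 log units; within the scatter), so a group with no chlorine, a five-membered aromatic ring and a hydrogen-bond donor reads here on a par with 2-chlorophenyl. The first of these steps gives only a lower bound on the change, because the value of compound 2 is a limit of the assay and not a number: the limit of > 64000 nM in this assay, at which 1 of the 3 values shown sits.

These compounds cannot separate the part played by the indole hydrogen on nitrogen from that of the added five-membered ring. Going by these compounds, how a pyridine or a carboxylic acid at this place would read also remains open.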